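A few compounds are considered here, and "the series" means these few. Any claim that something is new, unique, unknown or untested is made for them only; others in the source may bear on it.

Measured compounds in an ADME assay on HEK293 cells (Homo sapiens) for cytotoxicity; a lower number here means a stronger inhibitor, a higher number a weaker inhibitor:

compound 1, `CCCCCCCCCCCCCCNC(=O)[C@H](CO)/N=C/c1cccc(C)c1`: 51100 nM
compound 2, `CCCCCCCCCCCCCCNC(=O)[C@H](CO)/N=C/c1ccccc1OC`: 79200 nM
compound 3, `CCCCCCCCCCCCCCNC(=O)[C@H](CO)/N=C/c1ccc(O)cc1`: 71700 nM

Compound 1 has the lowest of the three numbers in this assay, yet its separation from the others is small: a 1.5-fold higher number from compound 1 to compound 2 (0.19 log units; within the scatter) and a 1.4-fold higher number from compound 1 to compound 3 (0.15 log units; within the scatter), both within the scatter. Compound 2 and compound 3 likewise sit together, a 1.1-fold lower number from compound 2 to compound 3 (0.04 log units; within the scatter). On these numbers the three aryl groups on the carbon with the double bond to nitrogen cannot be told apart.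

Compound 4, `CCCCCCCCCCCCCCNC(=O)[C@H](CO)/N=C/c1ccccc1C`, is not yet measured in this assay. It differs from compound 1 as follows: 2-methylphenyl in place of 3-methylphenyl on a carbon with a double bond to nitrogen. The measured steps that bear on this are the three exchanges of the aryl group just given, all within the scatter, so no step beyond the scatter in this assay is expected here either. Compound 4 is estimated at 56000 nM, range 30000 nM to 110000 nM, which means an expected step of a 1.1-fold higher number from compound 1 to compound 4 (0.04 log units; within the scatter).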

Compound 4, half-maximal inhibitory concentration: 81100 nM
Compound 4: middle estimate off by 1.4-fold (0.16 log units), on the low side, within the range that was stated.
By their numbers in this assay, from the lowest: compounds 1, 3, 2 and 4 (each within the scatter of the next).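

In this assay, within the data shown here, 2-methylphenyl in place of 3-methylphenyl on a carbon with a double bond to nitrogen gives a 1.6-fold higher number from compound 1 to compound 4 (0.20 log units; within the scatter) and is the first exchange here that keeps the atoms of the aryl group and changes only how they are joined, so this rearrangement of the methyl group gives no step beyond the scatter. Compound 4 also sits with the other two compounds, at a 1.1-fold higher number from compound 3 to compound 4 (0.05 log units; within the scatter) and a 1.0-fold higher number from compound 2 to compound 4 (0.01 log units; within the scatter) for methyl in place of methoxy on an aromatic carbon, so the four aryl groups cannot be told apart. No supporting evidence bears on this result.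

Still open, on these data alone, is whether an amine or a carboxylic acid on the aryl group would give a step beyond the scatter. The same question stands for a shorter or longer chain on the amide nitrogen.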